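From Phenyl to 4-Chlorophenyl: Expecting Compound 4

This account rests on a few compounds, and the source may have more. Where it says the series, first, only, none or still open, it means among the compounds named here.

Of the compounds shown here, three sharing one core have been measured. In a functional assay on PC-12 cells (Rattus norvegicus) for cytotoxicity, read by MTT assay, with stated times of 3 h and 2 h, tested at 1 uM (a higher number here means a stronger effect of the compound at the concentration tested, a lower number a weaker effect), compound 1 `O=C(CCCCC1CCSS1)NCc1cn(CCCOc2ccc3ccc(=O)oc3c2)nn1` gives 37.2%, compound 2 `O=C(CCCCC1CCSS1)NCc1cn(CCCOc2ccc3cc(C(=O)O)c(=O)oc3c2)nn1` gives 52.1%, and compound 3 `O=C(CCCCC1CCSS1)NCc1cn(CCCCOc2ccc3cc(-c4ccccc4)c(=O)oc3c2)nn1` gives 34.8%. Compound 3 holds the lowest of the three numbers; its gap to compound 1 lies within the scatter, while its gap to compound 2 lies beyond it. For the measured compounds named here, the only single-place step measured, a number 14.9 percentage points higher from compound 1 to compound 2 (beyond the scatter), concerns a carboxy group and does not touch the phenyl ring. Compound 4 `O=C(CCCCC1CCSS1)NCc1cn(CCCCOc2ccc3cc(-c4ccc(Cl)cc4)c(=O)oc3c2)nn1` differs from compound 3 by chloro in place of hydrogen on an aromatic carbon. Going by the values given here, no measured step bears on this change, so in this assay no step beyond the scatter is expected. Compound 4 is therefore expected to give 37%, between 25% and 50%. The expected step is a number 2.2 percentage points higher from compound 3 to compound 4 (within the scatter).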

Compound 4, a percentage reported as activity, at one concentration (the size of the read-out at that concentration, not a potency): 46.2%
Estimate against measurement, compound 4: 9.2 percentage points below; measured number inside the range.
By their numbers in this assay, from the lowest: compounds 3, 1, 4 and 2 (each within the scatter of the next, the first and the last beyond it).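

In this assay chloro in place of hydrogen gives a number 11.4 percentage points higher from compound 3 to compound 4 (beyond the scatter) and so shows that this place on the phenyl ring, para to a large group, responds to a single added chlorine atom. The earlier compounds shown here offered no step on this ring. No measurement shown here accounts for the rise.

As far as these compounds go, whether bromo, methoxy or an amine at the same place would move the number likewise remains open. So does whether chloro elsewhere on the phenyl ring would give a similar step.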